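Replacing piperidine with an arylamine on the shared core

The compounds below may be only part of what the source reports. "The series", "measured", "known", "first", "only" and "open" are said of these compounds alone.

Measured in a functional assay on HGC-27 cells (Homo sapiens) for cytotoxicity, read by MTT assay, with a stated time of 72 h (a lower number here means a stronger inhibitor, a higher number a weaker inhibitor), so far:
- compound 1 `CCCCCCCCNc1nc(SCc2ccc(C(F)(F)F)cc2)nc2ccccc12` gives 13400 nM
- compound 2 `CCCCCCCCCCCCNc1nc(SCc2ccc(C(F)(F)F)cc2)nc2ccccc12` gives 38700 nM
- compound 3 `FC(F)(F)c1ccc(CSc2nc(N3CCCCC3)c3ccccc3n2)cc1` reaches only the limit > 50000 nM, which is a limit of this assay and not a number

Among the measured compounds shown here, compound 3 therefore stands apart from the other two: it is the one whose value sits at the limit of > 50000 nM in this assay, at which 1 of the 3 values shown sits. Compound 4 `FC(F)(F)c1ccc(CSc2nc(Nc3ccccc3C(F)(F)F)c3ccccc3n2)cc1` differs from it in one place: (2-(trifluoromethyl)phenyl)amino in place of piperidin-1-yl on an aromatic carbon. For the measured compounds named here, two measured steps bear on this. The closest is an at least 3.7-fold higher number from compound 1 to compound 3 (0.57 log units; beyond the scatter), which involves the same position and shows that introducing piperidin-1-yl in place of an amino group carrying a hydrogen-bond donor weakened the compound by at least a modest amount. The other, a 2.9-fold higher number from compound 1 to compound 2 (0.46 log units; beyond the scatter), concerns only chain length and is less informative here. As far as these compounds go, since compound 4 restores a nitrogen with one hydrogen-bond donor at that position, a modest recovery is expected, though the aryl group is untested. The expected step is an at least 2.5-fold lower number from compound 3 to compound 4 (0.39 log units; beyond the scatter). Compound 4 is estimated at 20000 nM, within 6000 nM to 60000 nM.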

Compound 4, half-maximal inhibitory concentration: > 50000 nM
Compound 4 gave a limit, no number (the forecaster's own chance of this, stated with the estimate: 35%); at least 2.5-fold (0.39 log units) between middle value and limit.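

Compound 3 and compound 4 both stand at a limit of the assay and not at a number in this assay, so the step between them cannot be read: the limit of > 50000 nM in this assay, at which 2 of the 4 values shown sit.

The new information lies on the nitrogen itself: (2-(trifluoromethyl)phenyl)amino keeps a hydrogen-bond donor there, yet placing 2-(trifluoromethyl)phenyl on that nitrogen instead of octyl gives an at least 3.7-fold higher number from compound 1 to compound 4 (0.57 log units; beyond the scatter). A hydrogen-bond donor at this position is therefore not enough on its own to give a readable value, and among the compounds shown only compound 1 and compound 2, with a saturated chain on that nitrogen, give numbers.

As far as these compounds go, it remains open whether plain phenylamino, without the trifluoromethyl, would give a number. Also open, from the compounds shown here alone, is how a shorter chain such as butylamino would compare with octylamino.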